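A few compounds are considered here, and "the series" means these few. Any claim that something is new, unique, unknown or untested is made for them only; others in the source may bear on it.

Series notes. Compound 3 `Cc1ccccc1C(=O)NCc1ccc(CNS(=O)(=O)c2ccccc2Cl)cc1` in an assay on MDA-MB-231 cells for displacement of a labelled ligand from C-X-C chemokine receptor type 4 (Homo sapiens), read by fluorescence and microscopy, with stated times of 10 min and 30 min (a higher number here means that more compound is needed for the effect, a lower number that less compound is needed), gives 1000 nM, level at the digits shown with compound 2 `COc1ccccc1C(=O)NCc1ccc(CNS(=O)(=O)c2cccc(F)c2)cc1` at 1000 nM; together these are the highest of the three numbers, while compound 1 `O=C(NCc1ccc(CNS(=O)(=O)c2ccccc2Cl)cc1)c1cccnc1` gives 100 nM. Among the measured compounds shown here, the only single-change step measured is a 10-fold higher number from compound 1 to compound 3 (1.00 log units; beyond the scatter). Compound 4 `COc1ccccc1C(=O)NCc1ccc(CNS(=O)(=O)c2ccccc2Cl)cc1` differs from compound 3 by methoxy in place of methyl on an aromatic carbon. For the measured compounds named here, no measured step bears directly on this change; compound 2 carries the entering methoxy on the same ring and gives 1000 nM, though it differs from compound 4 elsewhere. The expected step is therefore no change at the digits printed from compound 3 to compound 4 (within the scatter), nothing beyond the scatter. The estimate for compound 4 in this assay is 1000 nM, within 300 nM to 3000 nM.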

Compound 4, effective concentration (reported as EC, without a stated level of effect): 100 nM
The estimate for compound 4 lay 10-fold (1.00 log units) above the measured number; the whole stated range lies above it.
By their numbers in this assay, from the lowest: compounds 1 and 4 (each within the scatter of the next); then compounds 2 and 3 (each within the scatter of the next).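

The change from methyl to methoxy on this aromatic carbon, ortho to a large group, gives a 10-fold lower number from compound 3 to compound 4 (1.00 log units; beyond the scatter) in this assay and so is not a neutral swap. The group on the sulfonyl sulfur also counts, with a 10-fold lower number from compound 2 to compound 4 (1.00 log units; beyond the scatter) for 2-chlorophenyl in place of 3-fluorophenyl, while 2-methoxyphenyl in place of pyridin-3-yl on the carbonyl carbon gives no change at the digits printed from compound 1 to compound 4 (within the scatter) overall. Nothing available accounts for the methoxy step. Open, from the compounds shown here alone, is how an ethoxy or an amine would read at this position. Also open, going by these compounds, is whether the methoxy step holds with other groups on the sulfonyl sulfur.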